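This account rests on a few compounds, and the source may have more. Where it says the series, first, only, none or still open, it means among the compounds named here.

Measured compounds:

compound 1, `Cc1c(OCCCCOc2ccc(Cl)c(C(=O)O)c2)ccc(C(=O)CC(C)(C)C)c1O`: 130 nM
compound 2, `Cc1ccc(OCCCCOc2ccc(C(=O)CC(C)(C)C)c(O)c2C)cc1C(=O)O`: 309 nM
compound 3, `Cc1ccc(OC[C@H](C)COc2ccc(C(=O)CC(C)(C)C)c(O)c2C)cc1C(=O)O`: a limit only, see below

All values come from an assay for positive allosteric modulation of metabotropic glutamate receptor 3 (Rattus norvegicus); a higher number here means that more compound is needed for the effect, a lower number that less compound is needed. Compound 1 gives 130 nM and compound 2 gives 309 nM in this assay. For compound 3 this assay gives only a limit, > 10000 nM, and no number.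

Compound 2 and compound 1 differ in one place: chloro in place of methyl on an aromatic carbon. The step in this assay is a 2.4-fold lower number from compound 2 to compound 1 (0.38 log units; beyond the scatter). Compound 3 shares its atoms with compound 2, joined differently; the difference between the two cores is not broken down here. What the two values show is that compound 3 sits at the limit of this assay, (the limit of > 10000 nM in this assay, at which 1 of the 3 values shown sits), while compound 2 gives a number.

Not yet measured is compound 4, `Cc1c(OC[C@@H](C)COc2ccc(Cl)c(C(=O)O)c2)ccc(C(=O)CC(C)(C)C)c1O`. It differs from compound 3 as follows: chloro in place of methyl on an aromatic carbon. This is the same change as from compound 2 to compound 1, made on the core of compound 3, and it occurs twice among the compounds shown.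

Within the data shown here, the one measured instance of this change gave a 2.4-fold lower number from compound 2 to compound 1 (0.38 log units; beyond the scatter). On that basis, the step is expected to be of similar size, an at least 1.1-fold lower number from compound 3 to compound 4 (0.04 log units; that floor lies within the scatter), though the starting point is only a limit. Compound 4 is thus estimated at 9000 nM, with a range of 3000 nM to 30000 nM, and a considerable chance that this assay again reports only a limit.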

Compound 4, half-maximal effective concentration: 2200 nM
Estimate against measurement, compound 4: 4.1-fold (0.61 log units) above; the measured number lies below the stated range.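

On the second core, chloro in place of methyl gives an at least 4.5-fold lower number from compound 3 to compound 4 (0.65 log units; beyond the scatter), which matches the direction already seen on the first core. Compound 3 gives only a limit, > 10000 nM, and no number, so the second step has a floor but no fixed size. The direction of the change therefore carries over on these two cores, but the data neither show that its size carries over nor establish a rule for other cores: the same change on two cores in this assay, a 2.4-fold lower number (0.38 log units; beyond the scatter) from compound 2 to compound 1 and an at least 4.5-fold lower number (0.65 log units; beyond the scatter) from compound 3 to compound 4; the limit leaves it open whether they differ

The compounds shown hold only methyl and chloro at this position, ortho to the carboxy group, so it remains open how a fluoro, bromo, trifluoromethyl or methoxy group there would read in this assay. Also open, from the compounds shown here alone, are whether the change holds on a core with a longer linking chain or with an amide in place of the carboxylic acid, and how large the second step is, which would take a number for compound 3 rather than a limit.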